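Notes on compound 3 after the sulfonyl-to-benzyl exchange

The source may hold more compounds than are shown below. What is called first, only, known or untested is meant among the compounds shown, and "the series" means these compounds.

Within the data shown here, in a functional assay on HeLa cells (Homo sapiens) for cytotoxicity, read by MTT assay, with a stated time of 48 h (a lower number here means a stronger inhibitor, a higher number a weaker inhibitor), compound 2 `CCN(CC)c1ccc2cc(C(=O)c3ccc(N4CCN(C(=O)CN5CCN(S(=O)(=O)c6ccc(F)cc6)CC5)CC4)cc3)oc2c1` gives 16700 nM, the highest of the two numbers measured so far; compound 1 `CCN(CC)c1ccc2cc(C(=O)c3ccc(N4CCN(C(=O)CN5CCN(S(=O)(=O)c6ccc(C#N)cc6)CC5)CC4)cc3)oc2c1` gives 8470 nM, and the step of a 2.0-fold higher number from compound 1 to compound 2 (0.29 log units; within the scatter) lies within the scatter. Compound 3 `CCN(CC)c1ccc2cc(C(=O)c3ccc(N4CCN(C(=O)CN5CCN(Cc6ccc(F)c(F)c6)CC5)CC4)cc3)oc2c1` differs from compound 2 by 3,4-difluorobenzyl in place of (4-fluorophenyl)sulfonyl on an amine nitrogen in a ring. Among the measured compounds shown here, no measured step bears on this change: the single step measured exchanges one substituent on an aromatic carbon, whereas here the entire group on the ring nitrogen is replaced. No movement beyond the scatter is expected in either direction, so the range is kept wide. Compound 3 is estimated at 12000 nM in this assay, between 4000 nM and 40000 nM, an expected step of a 1.4-fold lower number from compound 2 to compound 3 (0.14 log units; within the scatter).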

Compound 3, half-maximal inhibitory concentration: 6400 nM
Estimate against measurement, compound 3: 1.9-fold (0.27 log units) above, within the range that was stated.
By their numbers in this assay, from the lowest: compounds 3, 1 and 2 (each within the scatter of the next, the first and the last beyond it).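

Among these compounds, on this ring nitrogen the whole group can be exchanged and the sulfonyl link is not needed for a number in this range in this assay: 3,4-difluorobenzyl gives the first step here beyond the scatter (a 2.6-fold lower number from compound 2 to compound 3 (0.42 log units; beyond the scatter)), though a modest one. Against the nitrile-bearing sulfonyl the same group stays within the scatter (a 1.3-fold lower number from compound 1 to compound 3 (0.12 log units; within the scatter)). Nothing available explains the shift. The link and the ring fluorines change together, so their shares cannot be separated. Plain benzyl, an acetyl group or a free amine on this nitrogen remain open.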